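Sulfonamide swap on a shared kinase-like core

The source may hold more compounds than are shown below. What is called first, only, known or untested is meant among the compounds shown, and "the series" means these compounds.

Measured compounds:
- compound 1, `O=C(NCCNc1nccc(-c2c(-c3cccc(F)c3)nc3sccn23)n1)c1ccc(Cl)cc1`: 8160 nM
- compound 2, `O=C(NCCNc1nccc(-c2c(-c3cccc(F)c3)nc3sccn23)n1)c1ccccc1`: 17000 nM
- compound 3, `O=S(=O)(NCCNc1nccc(-c2c(-c3cccc(F)c3)nc3sccn23)n1)c1ccc(C(F)(F)F)cc1`: 8450 nM

All three were tested in a functional assay on SK-MEL-28 cells (Homo sapiens) for cytotoxicity, read by MTT assay; on this read-out lower numbers stand for stronger inhibition and higher numbers for weaker inhibition. Compound 3 sits second highest of the three numbers; its gap to compound 1 lies within the scatter, and so does its gap to compound 2, so no ordering among them can be claimed.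

Compound 4, `O=S(=O)(NCCNc1nccc(-c2c(-c3cccc(F)c3)nc3sccn23)n1)c1cccc(F)c1`, has not yet been measured. It differs from compound 3 by 3-fluorophenyl in place of 4-(trifluoromethyl)phenyl on a sulfonyl sulfur.

Among the compounds with values here, the only measured step, a 2.1-fold higher number from compound 1 to compound 2 (0.32 log units; beyond the scatter), concerns the amide pair and removes a halogen from the aromatic ring entirely. Within the data shown here, the change here is different in kind: one substituted phenyl ring is exchanged for another on the sulfonyl sulfur, and no measured step shows a sulfonamide variation. Among the measured compounds shown here, since the one step available points toward weaker inhibition when a ring substituent is lost, a small rise in the number is expected, roughly a 1.4-fold higher number from compound 3 to compound 4 (0.15 log units; within the scatter), though a result within the scatter would not surprise.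

Compound 4 is therefore estimated at 12000 nM, with a likely range from 5000 nM to 30000 nM.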

Compound 4, half-maximal inhibitory concentration: 18300 nM
Compound 4: middle estimate off by 1.5-fold (0.18 log units), on the low side; the range from low to high includes it.
By their numbers in this assay, from the lowest: compounds 1, 3, 2 and 4 (each within the scatter of the next, the first and the last beyond it).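

In this assay, within the data shown here, exchanging 4-(trifluoromethyl)phenyl for 3-fluorophenyl on the sulfonyl sulfur gives a 2.2-fold higher number from compound 3 to compound 4 (0.34 log units; beyond the scatter) and is the first sign that the ring on this sulfur can shift the number, so a sulfonamide link does not settle it alone. Set against the amides, the new compound shows a 1.1-fold higher number from compound 2 to compound 4 (0.03 log units; within the scatter) and this gap lies within the scatter, whereas a 2.2-fold higher number from compound 1 to compound 4 (0.35 log units; beyond the scatter) lies beyond it, which places compound 4 level with the unsubstituted benzoyl compound and not with the chlorinated one. Nothing measured here explains why the ring exchange has this effect.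

The exchange alters both the substituent and its place on the ring, and these two changes cannot be separated with the compounds shown. On these data alone, how an unsubstituted phenyl, or a phenyl carrying a nitrile or an amine, would behave on the sulfonyl sulfur remains open.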